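Carboxyaryl tail variation on the isoxazole-pyridine series

The source may report more compounds than this note shows. Statements on the series, on what has been measured and on what is new or still open speak of the compounds shown alone.

Measured so far in an assay on isolated protein for agonist activity at Bile acid receptor (Homo sapiens), read by FRET; a lower number here means that less compound is needed, a higher number that more compound is needed for the effect:
- compound 1, `CC(C)c1onc(-c2c(Cl)cccc2Cl)c1COc1ccc(N(C)C(=O)c2ccc(C(=O)O)cc2)c(C(F)(F)F)n1`, 235 nM
- compound 2, `CC(C)c1onc(-c2c(Cl)cccc2Cl)c1COc1ccc(N(C)Cc2cccc(C(=O)O)c2)c(C(F)(F)F)n1`, 12 nM
- compound 3, `CN(Cc1cccc(C(=O)O)c1)c1ccc(OCc2c(-c3c(Cl)cccc3Cl)noc2C2CC2)nc1C(F)(F)F`, 3 nM

Compound 3 gives the lowest number of the three. The step from compound 2 is a 4.0-fold lower number from compound 2 to compound 3 (0.60 log units; beyond the scatter), and the step within the tail, a 20-fold lower number from compound 1 to compound 2 (1.29 log units; beyond the scatter), is the largest seen. Compound 1 and compound 3 stand furthest apart, as their two values show.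

Compound 4, `O=C(O)c1ccc(OCc2ccc(OCc3c(-c4c(Cl)cccc4Cl)noc3C3CC3)nc2C(F)(F)F)cc1`, carries the change ((4-carboxyphenoxy)methyl in place of (3-carboxybenzyl)(methyl)amino on an aromatic carbon), set ortho to a trifluoromethyl group and two atoms from the ring nitrogen. Among the measured compounds shown here, the only step that bears on it is the tail exchange from compound 1 to compound 2, which was large and shows that the kind of link and the position of the carboxyl on this tail matter strongly. Compound 4 again changes both the link and the carboxyl position, so a step beyond the scatter in this assay is expected, most likely toward a higher number. Compound 4 is therefore estimated at 30 nM, range 5 nM to 200 nM, an expected step of a 10-fold higher number from compound 3 to compound 4 (1.00 log units; beyond the scatter).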

Compound 4, half-maximal effective concentration: 76 nM
The estimate for compound 4 lay 2.5-fold (0.40 log units) below the measured number, and the stated range covers the measured number.
By their numbers in this assay, from the lowest: compound 3; then compound 2; then compound 4; then compound 1.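

In this assay, a 25-fold higher number from compound 3 to compound 4 (1.40 log units; beyond the scatter) shows that the tail at this position, ortho to a trifluoromethyl group, still governs the number when the isoxazole carries cyclopropyl, a substituent the earlier tail step did not cover. The leaving and entering groups match in their carbon-only aromatic ring, hydrogen-bond donor and acceptor counts and lack of net charge, and differ by one heavy atom, so those counts do not separate them. No measurement available gives a reason for this step.

Going by these compounds, the exchange alters the link and the carboxyl placement together, so the share of each in the step remains open. Also open, on these data alone, is how this tail position would respond to a tetrazole in place of the carboxylic acid, or to a longer chain between the aromatic ring and the acid.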